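The source may hold more compounds than are shown below. What is called first, only, known or untested is meant among the compounds shown, and "the series" means these compounds.

Working notes on the series, acid dissociation.

Of the compounds shown here, two have been measured: compound 1 `COc1ccc(F)cc1CNCCCNc1ccnc2cc(Cc3cc(C)cc(C)c3)ccc12` and compound 2 `c1coc(CNCCCNc2ccnc3cc(CC4CCCCC4)ccc23)c1`. In a physicochemical assay for acid dissociation, compound 1 gives 9.47. In this assay compound 2 gives 9.47. Compound 1 is thus level with compound 2 at the digits shown; compound 2 is its nearest neighbour, and the two values differ by nothing beyond the usual scatter. For the measured compounds named here, compound 1 and compound 2 differ from each other in more than one place, so no single step can be drawn between them; all their two values show is that two quite different substitution patterns on the shared core return the same read-out.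

Compound 3 `COc1ccc(F)cc1CNCCCNc1ccnc2cc(-c3ccc(C(C)(C)C)cc3)ccc12` has not yet been measured. It differs from compound 1 in one place: 4-(tert-butyl)phenyl in place of 3,5-dimethylbenzyl on an aromatic carbon. Going by the values given here, no measured pair isolates this exchange, so the size of the step is not known from data. Given that compound 1 with 9.47 and compound 2 with 9.47 sit together despite broad structural differences, the expected step is a number 0.02 log units lower from compound 1 to compound 3 (within the scatter), that is, nothing beyond the scatter in either direction. Compound 3 is therefore estimated at 9.45, with a range from 9.15 to 9.75.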

Compound 3, acid dissociation constant: 9.47
The estimate for compound 3 lay 0.02 log units below the measured number, within the range that was stated.
By their numbers in this assay, from the lowest: compounds 1, 2 and 3 (each within the scatter of the next).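

In this assay, for the compounds shown here, 4-(tert-butyl)phenyl in place of 3,5-dimethylbenzyl on an aromatic carbon of the shared core gives no change at the digits printed from compound 1 to compound 3 (within the scatter), the first step that isolates a change in one place. At this position, the read-out does not separate these two groups, each with one six-membered aromatic ring of carbon only, no hydrogen-bond donors or acceptors and no net charge, so the agreement between compound 1 and compound 3 is tied to this single exchange rather than to the broad differences that separate compound 1 from compound 2. No independent evidence bears on why the read-out stays level across this exchange.

On these data alone, both groups consist of carbon only, so it remains open whether the read-out would hold at this position with a group carrying an amine or a carboxylic acid. Also open, as far as these compounds go, is whether a change elsewhere on the shared core, such as a longer chain in the linker, would leave the read-out level in the same way.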